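A Fluoro Group Added to Compound 3

The source may report more compounds than this note shows. Statements on the series, on what has been measured and on what is new or still open speak of the compounds shown alone.

Of the compounds shown here, three have been tested so far in a functional assay on MCF7 cells (Homo sapiens) for antiproliferative activity, read by sulforhodamine B assay, with a stated time of 48 h (on this read-out higher numbers stand for weaker inhibition and lower numbers for stronger inhibition), and their results differ widely. Compound 1 `COc1cc(OS(=O)(=O)c2ccc(N3CCN(C)C3=O)cc2)cc(OC)c1OC` gives 120 nM in this test. Compound 2 `CN1CCN(c2ccc(S(=O)(=O)Oc3ccc(F)cc3)cc2)C1=O` gives > 100000 nM as its result, which is a limit and not a number. Compound 3 `CCCCN1CCN(c2ccc(S(=O)(=O)Oc3ccccc3)cc2)C1=O` gives 8800 nM as its result, the higher of the two true numbers, and its gap to compound 1 lies beyond the usual scatter of repeated measurements.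

Compound 4 `CCCCN1CCN(c2ccc(S(=O)(=O)Oc3cccc(F)c3)cc2)C1=O` has not yet been measured. It carries fluoro in place of hydrogen on an aromatic carbon of compound 3, meta to a large group, so phenoxy becomes 3-fluorophenoxy fluoro in place of hydrogen on an aromatic carbon in this single change. Among the compounds with values here, no measured pair shows this change alone. With compound 3 at 8800 nM as the starting point, no step beyond the scatter is expected in this assay in either direction. The estimated step of a 1.1-fold lower number from compound 3 to compound 4 (0.04 log units; within the scatter) is therefore expected to be small. For compound 4 the expected value is 8000 nM with an estimated range from 2500 nM to 30000 nM in this test.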

Compound 4, half-maximal inhibitory concentration: 310 nM
Beside the measured number, compound 4's estimate is 26-fold (1.41 log units) above it; the whole stated range lies above it.
By their numbers in this assay, from the lowest: compound 1; then compound 4; then compound 3. At a limit, above all of these: compound 2.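

In this assay, swapping one hydrogen for fluoro on this aromatic carbon, which turns phenoxy into 3-fluorophenoxy, gives a 28-fold lower number from compound 3 to compound 4 (1.45 log units; beyond the scatter), so this single position on the ring has a large bearing on the result. The earlier compounds shown here could not show this, as no two of them differ in one place only, and here one added heavy atom, with no ring, no hydrogen-bond donor or acceptor and no net charge, is enough for a step of this size. Nothing at hand bears on why this change has so large an effect.

The compounds shown leave open whether the step belongs to fluoro alone or would also come with chloro or methoxy on the same carbon. They also leave open whether fluoro on another carbon of this ring would give a step of similar size.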